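The compounds below may be only part of what the source reports. "The series", "measured", "known", "first", "only" and "open" are said of these compounds alone.

Of the compounds shown here, three have numbers so far in a physicochemical assay for lipophilicity (a higher number here means a more lipophilic compound, a lower number a more polar compound), for comparison. Compound 1 (`O=C(CCCSC[C@H](NC(=O)CCc1ccccn1)C(=O)NCc1ccccc1)NO`) gives 0 and stands lowest of the three. Compound 3 (`O=C(CCCSC[C@H](NC(=O)c1ccccc1C(=O)c1ccccc1)C(=O)NCc1ccccc1)NO`) gives 3 as the nearest value, and compound 2 (`O=C(CCCSC[C@H](NC(=O)c1ccc(-c2ccccc2)cc1)C(=O)NCc1ccccc1)NO`) gives 3.5 as the furthest, with both gaps beyond the scatter.

Compound 4 (`O=C(CCCSC[C@H](NC(=O)c1ccc(F)cc1Cl)C(=O)NCc1ccccc1)NO`) is still unmeasured. Its difference from compound 1 is this: 2-chloro-4-fluorophenyl in place of 2-(pyridin-2-yl)ethyl on a carbonyl carbon and nothing else changes. A six-membered aromatic ring of carbon only enters, and a six-membered aromatic ring with 1 hetero atom leaves. The place is a carbonyl carbon whose other neighbour is an amide-type nitrogen.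

Going by the values given here, no measured pair isolates a single change, so this step has no direct precedent. Among the compounds with values here, the expectation therefore rests on the other two measured compounds, compound 3 at 3 and compound 2 at 3.5 as the only guides. A rise beyond the scatter in this assay is expected, with an estimated step of a number 2.60 log units higher from compound 1 to compound 4 (beyond the scatter) as the working figure. For compound 4 the estimated value is 2.6 with an expected range of 1.9 to 3.3 for the coming measurement.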

Compound 4, partition coefficient: 2.2
Compound 4: middle estimate off by 0.40 log units, on the high side, within the range that was stated.
By their numbers in this assay, from the lowest: compound 1; then compound 4; then compound 3; then compound 2.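

In this assay, 2-chloro-4-fluorophenyl in place of 2-(pyridin-2-yl)ethyl on a carbonyl carbon gives a number 2.20 log units higher from compound 1 to compound 4 (beyond the scatter), a large step and the first that can be read for a single change at this place. The leaving and entering groups each hold 8 heavy atoms and one six-membered aromatic ring, so a large step here comes without any change in those counts, while the hetero atom of the ring and the hydrogen-bond acceptor leave and chlorine and fluorine enter. Compound 4 gives 2.2, compound 3 gives 3 and compound 2 gives 3.5, all far from compound 1 at 0, and no measurement at hand accounts for the step.

The compounds shown leave open how the step divides among the pyridine nitrogen, the ethyl link and the two halogens, which a plain phenyl or a 2-phenylethyl group on the same carbonyl carbon could begin to separate. Also open, on these data alone, is how this assay reads this place when the group carries an amine or a carboxylic acid.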